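From (4-Methylbenzyl)amino to Anilino: Expecting Compound 4

The source may hold more compounds than are shown below. What is called first, only, known or untested is meant among the compounds shown, and "the series" means these compounds.

Compound 1 `CCOC(=O)[C@]1(C(=O)Nc2ccccc2)C[C@H]1c1cc(OC)c(OC)c(OC)c1` gives > 100000 nM in a functional assay on K562 cells (Homo sapiens) for cytotoxicity, read by MTT assay, with a stated time of 48 h; a higher number here means a weaker inhibitor, a lower number a stronger inhibitor; this is a limit of the assay, not a number.
Compound 2 `CCOC(=O)[C@]1(C(=O)NCc2ccc(C)cc2)C[C@H]1c1cc(OC)c(OC)c(OC)c1` gives > 100000 nM in this assay; this too is a limit.
Compound 3 `COc1cc([C@H]2C[C@]2(CO)C(=O)NCc2ccc(C)cc2)cc(OC)c1OC` gives > 100000 nM in this assay; this too is a limit.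

The change from compound 2 to compound 1 is phenyl in place of 4-methylbenzyl on an amide-type nitrogen, and the step that the two limits leave unreadable from compound 2 to compound 1 cannot be read, since both values are limits. The difference between the cores of compound 3 and compound 2 is not broken down here. Compound 4 `COc1cc([C@H]2C[C@]2(CO)C(=O)Nc2ccccc2)cc(OC)c1OC` is compound 3 with phenyl in place of 4-methylbenzyl on an amide-type nitrogen, the same change as from compound 2 to compound 1, made at the same place.

Because all three measured values sit at the limit of > 100000 nM in this assay, at which 3 of the 3 values shown sit, compound 4 is expected to remain at that limit as well. The step that the limit leaves unreadable from compound 3 to compound 4 is expected to be no more than the usual scatter. The estimate for compound 4 in this assay is 150000 nM, within 50000 nM to 500000 nM, most probably reported again only as a limit.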

Compound 4, half-maximal inhibitory concentration: > 100000 nM
Compound 4 gave a limit, no number; the forecaster's own chance of this, stated with the estimate: 85%; the middle value lies beyond the limit too.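

In this assay compound 4 gives > 100000 nM, which is a limit and not a number. Compound 3 gives > 100000 nM, also a limit, so no step can be read between compound 3 and compound 4, nor any other new step. The compounds shown leave open whether phenyl and 4-methylbenzyl on the amide-type nitrogen differ at all, and what would give a measurable value, since every result stands at one value: the limit of > 100000 nM in this assay, at which 4 of the 4 values shown sit.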